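The compounds below may be only part of what the source reports. "The series", "measured", "known", "first", "only" and "open" are said of these compounds alone.

In a functional assay on RAW264.7 cells (Mus musculus) for inhibition, read by Griess assay, with stated times of 2 h and 24 h (on this read-out higher numbers stand for weaker inhibition and lower numbers for stronger inhibition), compound 2 `COc1ccc([C@@H]2CC(=O)c3c(O)cc(OCc4cn(Cc5ccccc5)nn4)cc3O2)cc1O` gives 11000 nM, the lowest of the two numbers in hand; its nearest neighbour is compound 1 `COc1ccc([C@@H]2CC(=O)c3c(O)cc(OCc4cn(Cc5ccc(Cl)cc5)nn4)cc3O2)cc1O`, which gives 17800 nM, and the two are within the scatter of each other. Compound 3 `COc1ccc([C@@H]2CC(=O)c3c(O)cc(OCc4cn(Cc5cccc(Cl)c5)nn4)cc3O2)cc1O` differs from compound 2 by chloro in place of hydrogen on an aromatic carbon. Among the measured compounds shown here, the one measured step that bears on this is a 1.6-fold lower number from compound 1 to compound 2 (0.21 log units; within the scatter), in which a chloro group was taken off an aromatic carbon of the same benzyl ring with no effect beyond the scatter. Putting a chloro group back on, now at a different carbon of that ring, is therefore expected to leave this assay roughly unchanged, with no step beyond the scatter in either direction. For compound 3 the expected step is a 1.2-fold higher number from compound 2 to compound 3 (0.07 log units; within the scatter). Compound 3 is estimated at 13000 nM, with a likely range from 6000 nM to 30000 nM.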

Compound 3, half-maximal inhibitory concentration: 18200 nM
The estimate for compound 3 lay 1.4-fold (0.15 log units) below the measured number, within the range that was stated.
By their numbers in this assay, from the lowest: compounds 2, 1 and 3 (each within the scatter of the next).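

In this assay, among the compounds shown here, adding a chloro group to give the 3-chlorobenzyl compound produces a 1.7-fold higher number from compound 2 to compound 3 (0.22 log units; within the scatter), so a chloro group at this carbon, like the one in compound 1, leaves the number within the scatter of the unsubstituted benzyl compound. Moving the chloro group, going from 4-chlorophenyl to 3-chlorophenyl, produces a 1.0-fold higher number from compound 1 to compound 3 (0.01 log units; within the scatter), which means that across these three compounds the place of the chloro group makes no difference that can be read. No measurement at hand offers any explanation for this flat result.

The compounds shown carry only hydrogen or chloro on this ring. From the compounds shown here alone, whether a methoxy group, an amine or a carboxylic acid there would move the number beyond the scatter remains open, as does the effect of a longer chain in place of the benzyl group.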